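Dropping the Chloro Group from a Benzyl Substituent

The compounds below may be only part of what the source reports. "The series", "measured", "known", "first", "only" and "open" are said of these compounds alone.

Of the compounds shown here, three have been measured in a functional assay on RAW264.7 cells (Mus musculus) for inhibition, read by Griess assay, with stated times of 2 h and 24 h; on this read-out lower numbers stand for stronger inhibition and higher numbers for weaker inhibition. Compound 1 `CCCCn1cc(COc2cc(O)c3c(c2)O[C@H](c2ccc(OC)c(O)c2)C/C3=N\O)nn1` gives 8900 nM, compound 2 `COc1ccc([C@@H]2C/C(=N\O)c3c(O)cc(OCc4cn(CC5CC5)nn4)cc3O2)cc1O` gives 6320 nM, and compound 3 `COc1ccc([C@@H]2CC(=O)c3c(O)cc(OCc4cn(Cc5ccc(Cl)cc5)nn4)cc3O2)cc1O` gives 17800 nM, the highest of the three numbers. Compound 4 `COc1ccc([C@@H]2CC(=O)c3c(O)cc(OCc4cn(Cc5ccccc5)nn4)cc3O2)cc1O` differs from compound 3 by hydrogen in place of chloro on an aromatic carbon. Among the compounds with values here, the only measured step, a 1.4-fold lower number from compound 1 to compound 2 (0.15 log units; within the scatter), swaps groups on a saturated chain carbon bound to an aromatic nitrogen, a different kind of change, so it offers little guidance here. With nothing measured that bears on this change, no step beyond the scatter is expected. The estimated step is a 1.2-fold lower number from compound 3 to compound 4 (0.07 log units; within the scatter). Compound 4 is therefore expected to give about 15000 nM, with a range from 6000 nM to 40000 nM.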

Compound 4, half-maximal inhibitory concentration: 11000 nM
Beside the measured number, compound 4's estimate is 1.4-fold (0.13 log units) above it; the measured number falls inside the stated range.
By their numbers in this assay, from the lowest: compounds 2, 1, 4 and 3 (each within the scatter of the next, the first and the last beyond it).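

In this assay, taking the chloro group off the benzyl substituent gives a 1.6-fold lower number from compound 3 to compound 4 (0.21 log units; within the scatter), the only step shown at this place on the ring, para to a large group. The two compounds therefore cannot be told apart in this test, and compound 4 keeps its activity with hydrogen in place of chloro. Nothing available explains this result. Going by these compounds, whether an amine or a carboxylic acid at this same place would give a step beyond the scatter remains open. Also open, on these data alone, is whether the same swap would give a similar step on the core of compound 2.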